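The compounds below may be only part of what the source reports. "The series", "measured", "known", "first", "only" and "open" are said of these compounds alone.

Working notes on a set of biaryl phenols assessed in an assay for binding affinity to 17-beta-hydroxysteroid dehydrogenase type 2 (Homo sapiens), with a stated time of 20 min, tested at 1 uM; a higher number here means more inhibition at the concentration tested (going by the name of the read-out), a lower number less inhibition. Compound 1 `Oc1ccc2cc(-c3ccccc3O)ccc2c1` gives only a limit in this assay, < 10%, and no number. Compound 1 alone sits at the limit of < 10% in this assay, at which 1 of the 3 values shown sits. Compound 2 `Oc1cccc(-c2ccc3c(O)cccc3c2)c1` gives 32% in this assay. Compound 3 `OCc1ccc(-c2ccc3c(O)cccc3c2)cc1` gives 31% in this assay, a reading within the scatter of compound 2, so the two cannot be ranked against each other; of the two numbers in the set, compound 3 carries the lower one by a margin that means nothing.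

Compound 4 `N#Cc1ccc(-c2ccc3c(O)cccc3c2)cc1` has not yet been measured in this assay. The change from compound 3 to compound 4 is cyano in place of hydroxymethyl on an aromatic carbon. For the measured compounds named here, no measured pair in the set shows an exchange of this kind, so nothing here sets the size of the step; the set also lacks any measured property of the cyano or the hydroxymethyl that could be pointed to. The working expectation is a step no larger than the usual scatter, with no preferred direction, namely a number 1 percentage points lower from compound 3 to compound 4 (within the scatter). Compound 4 is therefore estimated at 30%, with a range from 12% to 50%, and a modest chance that this assay returns only a limit.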

Compound 4, a percentage reported as inhibition, at one concentration (the size of the read-out at that concentration, not a potency): 12%
Compound 4: middle estimate off by 18 percentage points, on the high side; low and high end bracket the measured number.
By their numbers in this assay, from the lowest: compound 4; then compounds 3 and 2 (each within the scatter of the next). At a limit, below all of these: compound 1.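

In this assay, for the compounds shown here, cyano in place of hydroxymethyl on an aromatic carbon gives the first step that can be read: a number 19 percentage points lower from compound 3 to compound 4 (beyond the scatter). The two groups have the same count of heavy atoms and sit para to a large group on a shared core, so this position is shown to respond to the identity of the group, even where that count stays the same; the counted differences are the hydrogen-bond donor that leaves with hydroxymethyl and the triple bond that enters with cyano. No measured property ties the step to either difference, so these counts remain a description of the change and not an account of it.

From the compounds shown here alone, a single exchange cannot separate the loss of the hydrogen-bond donor from anything particular to the nitrile, and how an amine or a carboxylic acid at this position would read in this assay stays open. Also open, going by these compounds, is whether the same exchange would give a step of similar size in the setting of compound 2.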